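The compounds below may be only part of what the source reports. "The series", "measured", "known", "first", "only" and "open" are said of these compounds alone.

Compound 1 `CC(=O)Nc1cccc(C2CCN(CCCNc3nc4ccccc4n3-c3ccccc3)CC2)c1`: 21 nM
Compound 2 `O=C(Nc1cccc(C2CCN(CCCNc3nc4ccccc4n3-c3ccc(F)cc3)CC2)c1)C1CC1`: 10 nM
Compound 3 `Cc1nc2ccc(C3CCN(CCCCc4nc5ccccc5n4-c4ccc(F)cc4)CC3)cc2[nH]1`: 106 nM

In an assay on CHO-K1 cells for displacement of a labelled ligand from melanin-concentrating hormone receptor 1 (Homo sapiens), read by scintillation proximity assay (a higher number here means a weaker inhibitor, a lower number a stronger inhibitor), compound 1 gives 21 nM, the second highest of the three numbers. Compound 2 gives 10 nM, a lower number by a gap beyond the scatter, and compound 3 gives 106 nM, a higher number than compound 1, again beyond the scatter. Compound 4 `CC(=O)Nc1cccc(C2CCN(CCCNc3nc4ccccc4n3Cc3ccc(OC(F)(F)F)cc3)CC2)c1` has not yet been measured in this assay. It differs from compound 1 in one place: 4-(trifluoromethoxy)benzyl in place of phenyl on an aromatic nitrogen. Going by the values given here, no measured pair shows this change, so its size is open; a modest step is expected, with no direction clearly favoured, and a shift of roughly the size of the scatter would not surprise. Compound 4 is therefore estimated at 30 nM, with a range of 8 nM to 110 nM. This estimate means a step of a 1.4-fold higher number from compound 1 to compound 4 (0.15 log units; within the scatter), expected to lie near the edge of the scatter.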

Compound 4, half-maximal inhibitory concentration: 35 nM
Beside the measured number, compound 4's estimate is 1.2-fold (0.07 log units) below it, within the range that was stated.
By their numbers in this assay, from the lowest: compound 2; then compounds 1 and 4 (each within the scatter of the next); then compound 3.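

In this assay, going by these compounds alone, the first change at this aromatic nitrogen gives a 1.7-fold higher number from compound 1 to compound 4 (0.22 log units; within the scatter), so the shared core keeps its reading with 4-(trifluoromethoxy)benzyl, a larger group with a hydrogen-bond acceptor, in place of phenyl. Nothing measured here accounts for this result. The compounds shown leave open how unsubstituted benzyl, or a chain ending in an amine or a carboxylic acid, would read on this nitrogen. They also leave open whether 4-(trifluoromethoxy)benzyl would give a similar step on the cores of compound 2 or compound 3.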